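Two Ways to Place a Chloromethyl Group on a Purine Core

The source may report more compounds than this note shows. Statements on the series, on what has been measured and on what is new or still open speak of the compounds shown alone.

Compound 1 `ClCc1ccc(Cn2cnc3nc(Cl)nc(Cl)c32)cc1` and compound 3 `ClCc1ccccc1Cn1cnc2nc(Cl)nc(Cl)c21` share the same atoms joined differently; the difference between the two cores is not broken down here. In a functional assay on K562 cells (Homo sapiens) for cytotoxicity, read by sulforhodamine B assay, with a stated time of 48 h (on this read-out higher numbers stand for lower toxicity in this test and lower numbers for higher toxicity in this test), compound 1 gives only a limit of > 100000 nM. Compound 3 likewise gives only a limit of > 100000 nM. Compound 2 `ClCc1ccccc1Cn1cnc2ncnc(Cl)c21` differs from compound 3 by hydrogen in place of chloro on an aromatic carbon and in this assay compound 2 gives 83200 nM, a step of an at least 1.2-fold lower number from compound 3 to compound 2 (0.07 log units; that floor lies within the scatter). Compound 4 `ClCc1ccc(Cn2cnc3ncnc(Cl)c32)cc1` carries the same change from compound 1, (hydrogen in place of chloro on an aromatic carbon). Resting on that step from compound 3 to compound 2, the expected step of an at least 1.0-fold lower number from compound 1 to compound 4 (0.02 log units; that floor lies within the scatter) is small, given (the limit of > 100000 nM in this assay, at which 2 of the 3 values shown sit). Compound 4 is therefore estimated at 95000 nM, between 50000 nM and 200000 nM, in this assay.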

Compound 4, concentration lethal to 50% of the cells: > 100000 nM
Compound 4 ended at the assay's limit (the forecaster's own chance of this, stated with the estimate: 55%); at least 1.0-fold (0.02 log units) between middle value and limit.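

Compound 1 and compound 4 both stop at a limit of the test, not at a true number, so no step between them can be read: the limit of > 100000 nM in this assay, at which 3 of the 4 values shown sit.

Going by these compounds, whether hydrogen in place of chloro changes toxicity on the core of compound 1 in this assay stays open.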